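A few compounds are considered here, and "the series" means these few. Any claim that something is new, unique, unknown or untested is made for them only; others in the source may bear on it.

Measured compounds:
- compound 1, `COc1cccc(NC(=O)Nc2ccc(Nc3ncnc4c3OCCN4)cc2)c1`: 6810 nM
- compound 2, `CC(C)(C)c1cc(NC(=O)Nc2ccc(Nc3ncnc4c3OCCN4)cc2)no1`: 10 nM
- compound 3, `O=C(Nc1ccc(Nc2ncnc3c2OCCN3)cc1)Nc1cccs1`: > 10000 nM

The three ureas share one core and differ only in the group on an amide-type nitrogen. In an assay on isolated protein for inhibition of proto-oncogene tyrosine-protein kinase receptor Ret (Homo sapiens), read by 33P incorporation, with stated times of 15 min and 40 min (a higher number here means a weaker inhibitor, a lower number a stronger inhibitor), compound 2 gives 10 nM while compound 1 gives 6810 nM; that is the step of a 680-fold lower number from compound 1 to compound 2 (2.83 log units; beyond the scatter). For compound 3 the value > 10000 nM is a limit of the assay, not a number (the limit of > 10000 nM in this assay, at which 1 of the 3 values shown sits). From there, an at least 1000-fold higher number from compound 2 to compound 3 (3.00 log units; beyond the scatter) and an at least 1.4-fold higher number from compound 1 to compound 3 (0.16 log units; that floor lies within the scatter); compound 3 thus stands at the weak end of what has been measured.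

Compound 4, `CC(C)(C)c1csc(NC(=O)Nc2ccc(Nc3ncnc4c3OCCN4)cc2)n1`, is not yet measured in this assay. It differs from compound 3 in one place: 4-(tert-butyl)-1,3-thiazol-2-yl in place of thiophen-2-yl on an amide-type nitrogen. The step that bears on it is an at least 1000-fold higher number from compound 2 to compound 3 (3.00 log units; beyond the scatter), read in reverse: the entering group, like the group of compound 2, carries a tert-butyl on a five-membered aromatic ring with 2 hetero atoms, whereas the leaving thiophen-2-yl has none. A large drop in this assay is therefore expected, an at least 400-fold lower number from compound 3 to compound 4 (2.60 log units; beyond the scatter). Compound 4 is expected to give about 25 nM, with a range from 5 nM to 300 nM.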

Compound 4, half-maximal inhibitory concentration: 3150 nM
Compound 4: the middle estimate sits 130-fold (2.10 log units) below what was measured, and the stated range ends below it.
By their numbers in this assay, from the lowest: compound 2; then compound 4; then compound 1. At a limit, above all of these: compound 3.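

Compound 3 stands at a limit of the assay, not at a number: the limit of > 10000 nM in this assay, at which 1 of the 4 values shown sits. In this assay, the 4-(tert-butyl)-1,3-thiazol-2-yl group gives an at least 3.1-fold lower number from compound 3 to compound 4 (0.50 log units; beyond the scatter), and its gain over the 3-methoxyphenyl group is only a 2.2-fold lower number from compound 1 to compound 4 (0.33 log units; beyond the scatter). Against the group of compound 2, the same change gives a 320-fold higher number from compound 2 to compound 4 (2.50 log units; beyond the scatter), so among these compounds a tert-butyl on a five-membered aromatic ring with 2 hetero atoms does not by itself bring a low number.

The compounds shown leave open how much of that gap belongs to the ring itself and how much to the way the tert-butyl is carried on it. They also leave open how an unsubstituted 1,3-thiazol-2-yl, or a 1,2-oxazol-3-yl bearing a cyclopropyl in place of the tert-butyl, would read in this assay.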